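Moving the Bromine on the Phenyl Ring

A few compounds are considered here, and "the series" means these few. Any claim that something is new, unique, unknown or untested is made for them only; others in the source may bear on it.

Compound 1, `Cc1cccc(N2CCC(C(=O)Nc3ccc4c(c3)NC(=O)CO4)CC2)c1`, gives 490 nM in a functional assay for antagonist activity at transient receptor potential cation channel subfamily V member 1 (Homo sapiens), read by FLIPR and calcium flux; a higher number here means a weaker inhibitor, a lower number a stronger inhibitor.
Compound 2, `O=C(Nc1ccc2cc[nH]c2c1)C1CCN(c2cccc(C(F)(F)F)c2)CC1`, reaches only the assay's limit, > 9000 nM.
Compound 3, `O=C1COc2ccc(NC(=O)C3CCN(c4ccccc4Br)CC3)cc2N1`, gives 160 nM.

Compound 3 holds the lowest of the two numbers measured, separated from compound 1 by a 3.1-fold lower number from compound 1 to compound 3 (0.49 log units; beyond the scatter). Compound 4, `O=C1COc2ccc(NC(=O)C3CCN(c4cccc(Br)c4)CC3)cc2N1`, differs from compound 3 by 3-bromophenyl in place of 2-bromophenyl on an amine nitrogen in a ring. Within the data shown here, only one measured step touches this ring: a 3.1-fold lower number from compound 1 to compound 3 (0.49 log units; beyond the scatter), which exchanged 3-methylphenyl for 2-bromophenyl and lowered the number. The 3-bromophenyl of compound 4 matches the 3-methylphenyl of compound 1 apart from the halogen, so the number is expected to move back toward that of compound 1, a modest rise, a 2.2-fold higher number from compound 3 to compound 4 (0.34 log units; beyond the scatter). Compound 4 is therefore estimated at 350 nM in this assay, most likely between 120 nM and 1000 nM.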

Compound 4, half-maximal inhibitory concentration: 330 nM
Beside the measured number, compound 4's estimate is 1.1-fold (0.03 log units) above it; the measured number falls inside the stated range.
By their numbers in this assay, from the lowest: compound 3; then compounds 4 and 1 (each within the scatter of the next). At a limit, above all of these: compound 2.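

Moving the bromine with no change of atoms gives a 2.1-fold higher number from compound 3 to compound 4 (0.31 log units; beyond the scatter), so in this assay the position of the bromine on this phenyl ring counts by itself, and 2-bromophenyl gives the lower number of the two. Bromo in place of methyl on an aromatic carbon gives a 1.5-fold lower number from compound 1 to compound 4 (0.17 log units; within the scatter), so this exchange does not separate the two compounds. Nothing shown here explains why position counts.

Going by these compounds, whether 2-chlorophenyl or 2-methylphenyl would match the number of compound 3 stays open, as does the effect of 4-bromophenyl.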